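The source may hold more compounds than are shown below. What is called first, only, known or untested is meant among the compounds shown, and "the series" means these compounds.

Compound 1 `C=CC1=C(C(=O)NCCC)C(c2ccc(F)cc2)OC1` and compound 2 `C=CC1=C(C(=O)NCCC)C(c2ccc(Cl)c(Cl)c2)OC1` share a core, and the difference between the two cores is not broken down here. In a functional assay on QGY7701 cells (Homo sapiens) for cytotoxicity, read by MTT assay, with a stated time of 24 h (a lower number here means a stronger inhibitor, a higher number a weaker inhibitor), compound 1 reaches only a limit, > 100000 nM. In this assay, going by the values given here, compound 2 gives 31300 nM, the only number among the three values shown. Compound 3 `C=CC1=C(C(=O)NCC(C)C)C(c2ccc(F)cc2)OC1` derives from compound 1 by one change, (methyl in place of hydrogen on a saturated chain carbon bound to two saturated chain carbons). In this assay compound 3 also reaches only a limit, > 100000 nM. The step that the two limits leave unreadable from compound 1 to compound 3 therefore cannot be read, because of the limit of > 100000 nM in this assay, at which 2 of the 3 values shown sit. Compound 4 `C=CC1=C(C(=O)NCC(C)C)C(c2ccc(Cl)c(Cl)c2)OC1` stands to compound 2 as compound 3 stands to compound 1, the same change, (methyl in place of hydrogen on a saturated chain carbon bound to two saturated chain carbons). The measured pair gives no readable size for it. The step from compound 2 to compound 4 is thus expected to be small, a 1.0-fold lower number from compound 2 to compound 4 (0.02 log units; within the scatter). Compound 4 is expected near 30000 nM, between 10000 nM and 100000 nM.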

Compound 4, half-maximal inhibitory concentration: > 100000 nM
Compound 4: a limit, no number; the forecaster's own chance of this, stated with the estimate: 25%; middle value at least 3.3-fold (0.52 log units) away from the limit.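

In this assay, on these data alone, the change of propyl to isobutyl on the core of compound 2 gives an at least 3.1-fold higher number from compound 2 to compound 4 (0.50 log units; beyond the scatter), a real loss of activity whose full size stays unknown. Compound 4 reaches only a limit, > 100000 nM. The same change on the core of compound 1 leaves a step that cannot be read, so the series does not show whether the change carries the same size from one core to the other: the limit of > 100000 nM in this assay, at which 3 of the 4 values shown sit.

The compounds shown leave open how a longer chain such as pentyl, or a chain carrying an amine or a carboxylic acid, would read in this assay on either core. They also leave open whether any such group would give a lower number than compound 2 gives.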